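Inverted Stereocentres in a Weakly Cytotoxic Pair

The source may hold more compounds than are shown below. What is called first, only, known or untested is meant among the compounds shown, and "the series" means these compounds.

Compound 1 `O=C(/C=C\c1ccc(O)cc1)O[C@H]1[C@H](O[C@@H]2CCCC[C@H]2O)O[C@H](CO)[C@@H](O)[C@@H]1O` was examined in a functional assay on SK-OV-3 cells (Homo sapiens) for cytotoxicity, read by sulforhodamine B assay; a lower number here means a stronger inhibitor, a higher number a weaker inhibitor. For compound 1 the result is only a limit of the assay, > 10000 nM. Compound 2 `O=C(OC[C@H]1O[C@@H](O[C@@H]2CCCC[C@H]2O)[C@H](O)[C@@H](O)[C@@H]1O)c1ccc(O)cc1` likewise yields only a limit in this assay, > 10000 nM. For the measured compounds named here, both results sit at the limit of > 10000 nM in this assay, at which 2 of the 2 values shown sit, so compound 1 stands at the same limit as the only other value shown. Compound 3 `O=C(/C=C\c1ccc(O)cc1)O[C@@H]1[C@H](O[C@H]2CCCC[C@@H]2O)O[C@H](CO)[C@@H](O)[C@H]1O` has not yet been measured; (the two compounds have the same atoms and bonds and differ only in configuration as drawn: 4 of 8 stereo elements differ; a stereocentre at a saturated ring carbon is drawn R in compound 1 and S in compound 3; a stereocentre at a saturated ring carbon is drawn R in compound 1 and S in compound 3; a stereocentre at a saturated ring carbon is drawn R in compound 1 and S in compound 3; a stereocentre at a saturated ring carbon is drawn S in compound 1 and R in compound 3). Going by the values given here, no step between measured compounds is available, and the step expected here is a step that the limit leaves unreadable from compound 1 to compound 3, which is none beyond the scatter. Compound 3 is therefore expected to give about 15000 nM, between 8000 nM and 50000 nM, most probably again as a limit only.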

Compound 3, half-maximal inhibitory concentration: > 10000 nM
Compound 3 gave a limit, no number; the forecaster's own chance of this, stated with the estimate: 90%; the middle value does not contradict the limit.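

For the compounds shown here, compound 3 gives only a limit in this assay, > 10000 nM, so no step from compound 1 to compound 3 can be read. Whether configuration matters for cytotoxicity at all stays open, as no compound shown gives a number: the limit of > 10000 nM in this assay, at which 3 of the 3 values shown sit.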